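Chloro to tert-butyl: expected cytotoxicity of compound 3

A few compounds are considered here, and "the series" means these few. Any claim that something is new, unique, unknown or untested is made for them only; others in the source may bear on it.

Measured so far in an ADME assay on L02 cells (Homo sapiens) for cytotoxicity, read by MTT assay, with a stated time of 48 h; on this read-out lower numbers stand for stronger inhibition and higher numbers for weaker inhibition:
- compound 1 `O=c1ccoc2cc(OCc3cn(Cc4ccc(Cl)cc4)nn3)ccc12` gives > 300000 nM, which is a limit of the assay and not a number.
- compound 2 `O=c1ccoc2cc(OCc3cn(Cc4cccc(Cl)c4)nn3)ccc12` gives > 300000 nM, likewise a limit of the assay.

Compound 1 therefore stands only at a limit in this assay, and the other measured compound stands at a limit too. Both values sit at the limit of > 300000 nM in this assay, at which 2 of the 2 values shown sit. Going by the values given here, for that reason the one measured step, a step that the two limits leave unreadable from compound 1 to compound 2, with 3-chlorophenyl in place of 4-chlorophenyl on a saturated chain carbon bound to an aromatic nitrogen, cannot be read in either direction.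

Compound 3 `CC(C)(C)c1ccc(Cn2cc(COc3ccc4c(=O)ccoc4c3)nn2)cc1` differs from compound 1 by tert-butyl in place of chloro on an aromatic carbon of a six-membered aromatic ring of carbon only, para to a large group. Among the compounds with values here, no measured step touches this change, and the only measured step is unreadable, so nothing points to a move beyond the scatter. The expectation is that compound 3 also shows no measurable inhibition in this assay, with an estimated value of 400000 nM and a range from 150000 nM to 1000000 nM. The step this estimate implies from compound 1 is expected to be a step that the limit leaves unreadable from compound 1 to compound 3.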

Compound 3, half-maximal inhibitory concentration: > 300000 nM
Compound 3 ended at the assay's limit; the forecaster's own chance of this, stated with the estimate: 85%; the middle value does not contradict the limit.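

Compound 1, compound 2 and compound 3 all stand only at a limit in this assay, so no step among them can be read: the limit of > 300000 nM in this assay, at which 3 of the 3 values shown sit.

The compounds shown leave open whether tert-butyl in place of chloro, or 3-chlorophenyl in place of 4-chlorophenyl, changes cytotoxicity at all, and what change to these structures would give a readable value in this assay.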